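Adding one methyl to compound 1

The source may hold more compounds than are shown below. What is called first, only, known or untested is meant among the compounds shown, and "the series" means these compounds.

Values in a physicochemical assay for lipophilicity, read by HPLC, at pH 7.5 (on this read-out higher numbers stand for higher lipophilicity and lower numbers for lower lipophilicity), so far:
Compound 1 (`N#Cc1c(-c2ccc(Br)cc2)nc2cnccc2c1NCC(N)=O`) gives (1.9)
Compound 2 (`CC[C@@H](Nc1c(C#N)c(-c2ccc(-c3cccc(C)c3)cc2)nc2cnccc12)C(N)=O`) gives (3)

Compound 1 stands lowest of the two measured compounds, and compound 2 lies above it by more than the usual scatter. These two differ in more than one place, so their gap cannot be assigned to any single change. Compound 3 (`CC(Nc1c(C#N)c(-c2ccc(Br)cc2)nc2cnccc12)C(N)=O`) departs from compound 1 in one place (methyl in place of hydrogen on a saturated chain carbon bound to a carbonyl carbon and a nitrogen on an aromatic ring), with methyl in place of hydrogen on a saturated chain carbon bound to a carbonyl carbon and a nitrogen on an aromatic ring. For the measured compounds named here, no measured pair isolates this change. A small upward step in this assay is expected, near the edge of the scatter (a number 0.40 log units higher from compound 1 to compound 3 (beyond the scatter)). Compound 3 is expected at (2.3), with an estimated range from (2) to (2.6).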

Compound 3, distribution coefficient: 2.1
Beside the measured number, compound 3's estimate is 0.20 log units above it; low and high end bracket the measured number.
By their numbers in this assay, from the lowest: compounds 1 and 3 (each within the scatter of the next); then compound 2.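

Methyl in place of hydrogen on a saturated chain carbon bound to a carbonyl carbon and a nitrogen on an aromatic ring gives a number 0.20 log units higher from compound 1 to compound 3 (within the scatter) in this assay, the first pair to isolate this change. At this position, the single added carbon does not separate the two compounds on this read-out. No measured evidence bears on why this is so. Going by these compounds, it remains open whether a hydroxymethyl group or an aminomethyl group at this carbon would also stay within the scatter. So does the outcome of replacing the carbamoyl group with a carboxylic acid.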